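Swapping the arylamino substituent for a benzylamino group

A few compounds are considered here, and "the series" means these few. Any claim that something is new, unique, unknown or untested is made for them only; others in the source may bear on it.

Measured compounds:
- compound 1, `CCCCOC1=C(C(=O)c2ccccc2)C(c2ccc(Br)cc2)N(CCCn2ccnc2)C1=O`: 17100 nM
- compound 2, `O=C(C1=C(Nc2ccc(Br)cc2)C(=O)N(CCCn2ccnc2)C1c1ccc(Br)cc1)c1ccccc1`: 19300 nM
- compound 3, `O=C(C1=C(Nc2ccc(OC(F)(F)F)cc2)C(=O)N(CCCn2ccnc2)C1c1ccc(Br)cc1)c1ccccc1`: 11500 nM

In a functional assay on NCI-H1299 cells (Homo sapiens) for antiproliferative activity, read by MTT assay, with a stated time of 72 h (on this read-out lower numbers stand for stronger inhibition and higher numbers for weaker inhibition), compound 3 returns the lowest of the three numbers, yet its nearest neighbour compound 1 and furthest neighbour compound 2 both lie within the scatter: a 1.5-fold lower number from compound 1 to compound 3 (0.17 log units; within the scatter) and a 1.7-fold lower number from compound 2 to compound 3 (0.22 log units; within the scatter). Among the measured compounds shown here, no compound here is separated from another beyond the scatter.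

Compound 4, `O=C(C1=C(NCc2ccccc2)C(=O)N(CCCn2ccnc2)C1c1ccc(Br)cc1)c1ccccc1`, differs from compound 3 in one place: benzyl in place of 4-(trifluoromethoxy)phenyl on an amine nitrogen. For the measured compounds named here, no measured pair covers this exact exchange. The closest guidance comes from the changes at the same position, a 1.1-fold higher number from compound 1 to compound 2 (0.05 log units; within the scatter) and a 1.5-fold lower number from compound 1 to compound 3 (0.17 log units; within the scatter), and at the aromatic ring, a 1.7-fold lower number from compound 2 to compound 3 (0.22 log units; within the scatter), none of which left the scatter. The account therefore expects no step beyond the scatter from compound 3 to compound 4, namely a 1.1-fold higher number from compound 3 to compound 4 (0.05 log units; within the scatter). Compound 4 is estimated at 13000 nM, between 6000 nM and 30000 nM.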

Compound 4, half-maximal inhibitory concentration: 25300 nM
Beside the measured number, compound 4's estimate is 1.9-fold (0.29 log units) below it; low and high end bracket the measured number.
By their numbers in this assay, from the lowest: compounds 3, 1, 2 and 4 (each within the scatter of the next, the first and the last beyond it).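

In this assay, among the compounds shown here, benzyl in place of 4-(trifluoromethoxy)phenyl on the amine nitrogen gives the first step beyond the scatter in this set, a 2.2-fold higher number from compound 3 to compound 4 (0.34 log units; beyond the scatter), so the group at this position can move the number. The separation holds against one neighbour only, since the other steps to the benzyl compound stay small: a 1.3-fold higher number from compound 2 to compound 4 (0.12 log units; within the scatter) and a 1.5-fold higher number from compound 1 to compound 4 (0.17 log units; within the scatter). No measurement shown here accounts for the step. Going by these compounds, whether a longer chain in place of benzyl, or a carboxylic acid on its ring, would shift the number remains open.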